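An Acetylated Ring on the Amide of Compound 3

The source may report more compounds than this note shows. Statements on the series, on what has been measured and on what is new or still open speak of the compounds shown alone.

Measured so far in a physicochemical assay for solubility, read by spectrophotometry, measured as kinetic solubility, at pH 8, tested at 500 uM; on this read-out higher numbers stand for higher solubility and lower numbers for lower solubility:
compound 1 `CNC(=O)c1ccncc1Nc1cc(-c2ccc3ccn(C)c3c2)c2nccnc2c1`: 4 ug/mL
compound 2 `CC(=O)N1CCC(NC(=O)c2ccncc2Nc2cc(-c3ccc4ccn(C)c4c3)c3nccnc3c2)CC1`: 213 ug/mL
compound 3 `CN1CC(NC(=O)c2ccncc2Nc2cc(-c3ccc4ccn(C)c4c3)c3nccnc3c2)C1`: 170 ug/mL

Compound 3 stands in the upper pair of this small set, and the gap within that pair does not exceed the scatter: a 1.3-fold lower number from compound 2 to compound 3 (0.10 log units; within the scatter). Replacing the methyl on the amide-type nitrogen produced two large steps, a 53-fold higher number from compound 1 to compound 2 (1.73 log units; beyond the scatter) and a 43-fold higher number from compound 1 to compound 3 (1.63 log units; beyond the scatter).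

Compound 4 `CC(=O)N1CCC(NC(=O)c2ccncc2Nc2cc(-c3ccc4ccn(C)c4c3)c3nccnc3c2)C1` carries 1-acetylpyrrolidin-3-yl in place of 1-methylazetidin-3-yl on an amide-type nitrogen. Among the compounds with values here, no measured step makes this exact exchange. The closest guide is compound 2, which also bears an acetylated ring, and its value of 213 ug/mL suggests that compound 4 should stay in the upper pair, far from compound 1. The expected step is a 1.1-fold higher number from compound 3 to compound 4 (0.05 log units; within the scatter), which would be none beyond the scatter. Compound 4 is estimated at 190 ug/mL, with an expected range of 90 ug/mL to 270 ug/mL.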

Compound 4, solubility: 253 ug/mL
Compound 4: the middle estimate sits 1.3-fold (0.12 log units) below what was measured; low and high end bracket the measured number.
By their numbers in this assay, from the lowest: compound 1; then compounds 3, 2 and 4 (each within the scatter of the next).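

In this assay a third ring on the amide-type nitrogen, 1-acetylpyrrolidin-3-yl, again gives a large step away from methyl, namely a 63-fold higher number from compound 1 to compound 4 (1.80 log units; beyond the scatter) in this case. The steps of a 1.5-fold higher number from compound 3 to compound 4 (0.17 log units; within the scatter) and a 1.2-fold higher number from compound 2 to compound 4 (0.07 log units; within the scatter) do not set it apart from the other two rings. All three rings, whether capped with methyl or acetyl and whether four-membered or five-membered in the two cases counted here, therefore stand together far from compound 1, and no compound shown goes against this.

The compounds shown leave open whether a longer chain ending in a hydroxyl or a plain cyclohexyl ring would give a step of the same size. Nothing given here accounts for the distance between these rings and methyl at this position.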